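The source may report more compounds than this note shows. Statements on the series, on what has been measured and on what is new or still open speak of the compounds shown alone.

Measured compounds:
- compound 1 `CN(C[C@H]1Cc2c(cccc2N2CCN(Cc3ccccn3)CC2)CN1)[C@H]1CCCc2cccnc21`: in an ADME assay on microsomes from liver (Homo sapiens) for metabolic stability, read by LC-MS, with a stated time of 10 min (on this read-out lower numbers stand for a less stable compound and higher numbers for a more stable compound), compound 1 gives 4.2%
- compound 2 `CCCN(C[C@H]1Cc2c(cccc2N2CCNCC2)CN1)[C@H]1CCCc2cccnc21`: in this assay compound 2 gives 100%

Compound 1 stands lowest of the two numbers; the nearest value, that of compound 2, lies far higher, well beyond the scatter. Among the compounds with values here, compound 2 differs from compound 1 in more than one place, so no single step is drawn between them; their two values only show that the shared core can reach the top of the read-out.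

Compound 3 `CN(C[C@H]1Cc2c(cccc2N2CCN(C3COC3)CC2)CN1)[C@H]1CCCc2cccnc21` is the next entry, not yet measured. Compared with compound 1 it carries oxetan-3-yl in place of (pyridin-2-yl)methyl on an amine nitrogen in a ring. Compound 1 stands lowest of the two numbers in this assay with 4.2%, so the step from compound 1 to compound 3 is expected to go upward and to be of moderate size, since the amine in the ring no longer bears the (pyridin-2-yl)methyl group: a number 30.8 percentage points higher from compound 1 to compound 3 (beyond the scatter). Compound 3 is therefore estimated at 35%, within 10% to 70%.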

Compound 3, percent of the compound remaining: 83.1%
For compound 3 the middle estimate is 48.1 percentage points below the measured one; measured number above the stated range.
By their numbers in this assay, from the lowest: compound 1; then compound 3; then compound 2.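

The ring amine nitrogen of the six-membered ring with two nitrogens proves to be a decisive place in this assay, with a single change there giving a number 78.9 percentage points higher from compound 1 to compound 3 (beyond the scatter). The low number of compound 1 therefore does not belong to the shared core alone, as compound 3 keeps that core and gives 83.1% in this read-out. The step swaps an aromatic six-membered ring for a non-aromatic four-membered ring and also lowers the heavy-atom count, and nothing measured on these compounds accounts for the rise.

Open, from the compounds shown here alone, is which part of the change carries the step: a benzyl group, an acetyl group or a plain methyl group on this nitrogen would help to separate these features. Also open, going by these compounds, is whether oxetan-3-yl gives a similar step when the other amine of the core carries a longer chain.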